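The source may hold more compounds than are shown below. What is called first, only, known or untested is meant among the compounds shown, and "the series" means these compounds.

Of the compounds shown here, two sharing one core have been tested in an ADME assay on Huh-7 cells (Homo sapiens) for cytotoxicity, with a stated time of 72 h; a lower number here means that less compound is tolerated, a higher number that more compound is tolerated. Compound 1 `CC(C)CCn1nc(-c2cccs2)c(O)c(C2=NS(=O)(=O)c3cc(OCC(N)=O)ccc3N2)c1=O` gives 78000 nM there. Among the compounds with values here, compound 2 `CC(C)CCn1nc(-c2cccs2)c(O)c(C2=NS(=O)(=O)c3cc(OC(C)C(N)=O)ccc3N2)c1=O` gives 68000 nM in this assay, which is the lowest of the two numbers, with compound 1 as its only neighbour, and the single step of a 1.1-fold lower number from compound 1 to compound 2 (0.06 log units; within the scatter) stays within the usual scatter of repeated measurements.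

Compound 3 `CC(C)CCn1nc(-c2cccs2)c(O)c(C2=NS(=O)(=O)c3cc(OC(C)(C)C(N)=O)ccc3N2)c1=O` has not yet been measured in this assay. It differs from compound 2 by methyl in place of hydrogen on a saturated chain carbon bound to a carbonyl carbon, an oxygen on an aromatic ring and a saturated chain carbon, so 1-carbamoylethoxy becomes 1-carbamoyl-1-methylethoxy. Within the data shown here, the only step that bears on this change is the one from compound 1 to compound 2, where adding one methyl at the same chain carbon left the number unchanged beyond the scatter. A second methyl is therefore expected to give a step of a 1.0-fold lower number from compound 2 to compound 3 (0.02 log units; within the scatter), again without clear direction. Compound 3 is estimated at 65000 nM in this assay, with a range from 35000 nM to 120000 nM.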

Compound 3, half-maximal cytotoxic concentration: > 33000 nM
Compound 3: no number, only a limit; the forecaster's own chance of this, stated with the estimate: 20%; the middle value is on the limit's open side.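

In this assay compound 3 gives > 33000 nM, which is a limit and not a number, so its steps from compound 1 and compound 2 cannot be read. The compounds shown leave open whether 1-carbamoyl-1-methylethoxy in place of 1-carbamoylethoxy changes the tolerated concentration at all.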